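This account rests on a few compounds, and the source may have more. Where it says the series, first, only, none or still open, it means among the compounds named here.

Series values in a functional assay on MCF7 cells (Homo sapiens) for antiproliferative activity, read by sulforhodamine B assay, with a stated time of 48 h; a lower number here means a stronger inhibitor, a higher number a weaker inhibitor:
- compound 1 `COc1ccc(C[C@@H](O)/C=C/C=C/C(=O)N2CCCCC2)cc1OC`: 39500 nM
- compound 2 `CCN1CCN(C(=O)/C=C/C=C/[C@H](O)Cc2ccc(OC)c(OC)c2)CC1`: 11500 nM

Going by the values given here, of the two measured compounds, compound 2 has the lower number, 11500 nM, and the only neighbour is compound 1 at 39500 nM.

The next compound is compound 3 `COc1ccc(C[C@@H](O)/C=C/C=C/C(=O)NCc2ccccc2)cc1OC`, with benzylamino in place of 4-ethylpiperazin-1-yl on a carbonyl carbon.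

Among the compounds with values here, only one measured step changes the group at this place, a 3.4-fold lower number from compound 1 to compound 2 (0.54 log units; beyond the scatter), which is modest but beyond the scatter. Neither measured compound carries benzylamino, so the data give no direct reading of this group and the direction remains uncertain. Within the data shown here, with compound 2 at 11500 nM as the lower of only two numbers, a modest move upward in this assay is expected, of about the same size as the one measured step. The expected change is a 2.2-fold higher number from compound 2 to compound 3 (0.34 log units; beyond the scatter). For compound 3 the estimated value is 25000 nM, with an expected range from 8000 nM to 60000 nM.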

Compound 3, half-maximal inhibitory concentration: 33600 nM
Compound 3: the middle estimate sits 1.3-fold (0.13 log units) below what was measured; low and high end bracket the measured number.
By their numbers in this assay, from the lowest: compound 2; then compounds 3 and 1 (each within the scatter of the next).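

In this assay, benzylamino in place of 4-ethylpiperazin-1-yl on the carbonyl carbon gives a 2.9-fold higher number from compound 2 to compound 3 (0.47 log units; beyond the scatter) and so does not keep the lower number of compound 2, even though both groups have the same heavy-atom count. Benzylamino in place of piperidin-1-yl gives a 1.2-fold lower number from compound 1 to compound 3 (0.07 log units; within the scatter) and leaves these two groups indistinguishable in this assay, so among the three groups shown at this place, only 4-ethylpiperazin-1-yl stands apart, with the lowest number. No measurement at hand gives a reason for this difference.

The change from 4-ethylpiperazin-1-yl to benzylamino swaps a non-aromatic ring with two hetero atoms for an aromatic carbon ring and also brings in a hydrogen-bond donor, so this single step cannot separate those features, and an N-methyl-N-benzylamino group would be needed to test the donor alone. On these data alone, whether the lower number of compound 2 depends on the ethyl group or on the second ring nitrogen remains open, a question that piperazin-1-yl without the ethyl group and morpholin-4-yl would address.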